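The source may report more compounds than this note shows. Statements on the series, on what has been measured and on what is new or still open speak of the compounds shown alone.

Measured so far:
compound 1 `O=C(Nc1cccc(-c2nc(-c3ccc(NC(=O)c4cccnc4)cc3Cl)no2)c1)c1ccccc1` — 12800 nM
compound 2 `CC(=O)Nc1ccc(S(=O)(=O)Nc2cccc(-c3nc(-c4ccc(NC(=O)c5cccnc5)c(C(F)(F)F)c4)no3)c2)cc1` — > 10000 nM

In a functional assay on MDA-MB-231 cells (Homo sapiens) for antiproliferative activity, read by MTT assay, with a stated time of 72 h (a higher number here means a weaker inhibitor, a lower number a stronger inhibitor), compound 1 gives 12800 nM. Compound 2 is reported only as a limit of the assay, > 10000 nM, and no number stands beside it. Among the values shown, compound 1 therefore carries the only measured number, while the other entry is a limit (the limit of > 10000 nM in this assay, at which 1 of the 2 values shown sits). Compound 2 differs from compound 1 in more than one place, so the two values together show only that both sit in the weak range of this assay.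

Compound 3 `Cc1ccc(NC(=O)Nc2cccc(-c3nc(-c4ccc(NC(=O)c5cccnc5)cc4Cl)no3)c2)cc1` keeps the core of compound 1 and alters one group: (4-methylphenyl)amino in place of phenyl on a carbonyl carbon, in words (4-methylphenyl)amino in place of phenyl on a carbonyl carbon. Going by the values given here, no measured pair reflects this change, so no direction is given by the data. The step from compound 1 to compound 3 is expected as a 1.2-fold lower number from compound 1 to compound 3 (0.07 log units; within the scatter), no larger than the scatter and of undetermined sign. Compound 3 is expected at 11000 nM, in a range from 3500 nM to 35000 nM. A fair chance remains that compound 3 is reported only as a limit, as compound 2 is.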

Compound 3, half-maximal inhibitory concentration: 3500 nM
Compound 3: middle estimate off by 3.1-fold (0.50 log units), on the high side, within the range that was stated.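

In this assay, going by these compounds alone, the replacement of phenyl by (4-methylphenyl)amino on a carbonyl carbon gives a 3.7-fold lower number from compound 1 to compound 3 (0.56 log units; beyond the scatter), the first step that can be read. This shows what compound 1 and compound 2 could not: the position responds to a change of group, and benzamido to ((4-methylphenyl)carbamoyl)amino is a modest gain that lies beyond the scatter. The nitrogen and the methyl group enter together in this one change, so the step cannot be divided between them, and nothing measured here gives a reason for it.

Still open, on these data alone, is which of the two parts carries the step: phenylamino, without the methyl group, or 4-methylphenyl, without the nitrogen, on the same carbonyl carbon would separate them. Compound 2 gives no number to help with this, as it stands only as a limit of the assay: the limit of > 10000 nM in this assay, at which 1 of the 3 values shown sits.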